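The compounds below may be only part of what the source reports. "The series", "measured", "known", "first", "only" and "open" are said of these compounds alone.

Measured in a functional assay on HepG2 cells (Homo sapiens) for inhibition, read by MTT assay, with a stated time of 72 h; a lower number here means a stronger inhibitor, a higher number a weaker inhibitor: compound 1 `O=C(Nc1cccc(OCc2cn(-c3cccc(Br)c3)nn2)c1)Nc1ccc(Cl)c(C(F)(F)F)c1`, 1040 nM; compound 2 `O=C(Nc1cccc(OCc2cn(-c3ccc(Br)cc3)nn2)c1)Nc1ccc(Cl)c(C(F)(F)F)c1`, 2730 nM.

Among the measured compounds shown here, compound 2 holds the highest number of the two measured, and the only step available is a 2.6-fold higher number from compound 1 to compound 2 (0.42 log units; beyond the scatter). Compound 3 `O=C(Nc1cccc(OCc2cn(-c3ccccc3I)nn2)c1)Nc1ccc(Cl)c(C(F)(F)F)c1` differs from compound 2 by 2-iodophenyl in place of 4-bromophenyl on an aromatic nitrogen. For the measured compounds named here, that single step is the only guide; it changed only where the bromine sits on the phenyl and gave a modest shift, while here both the halogen and its position change, so a shift of similar size is expected, direction uncertain. Compound 3 is therefore expected near 2000 nM, range 600 nM to 7000 nM, meaning an expected step of a 1.4-fold lower number from compound 2 to compound 3 (0.14 log units; within the scatter) in this assay .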

Compound 3, half-maximal inhibitory concentration: 2870 nM
Compound 3: the middle estimate sits 1.4-fold (0.16 log units) below what was measured; low and high end bracket the measured number.
By their numbers in this assay, from the lowest: compound 1; then compounds 2 and 3 (each within the scatter of the next).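

In this assay, 2-iodophenyl in place of 4-bromophenyl gives a 1.1-fold higher number from compound 2 to compound 3 (0.02 log units; within the scatter), so this change of both halogen and ring position leaves the number within the scatter. The change from 3-bromophenyl to 2-iodophenyl gives a 2.8-fold higher number from compound 1 to compound 3 (0.44 log units; beyond the scatter), so among these three compounds, only the 3-bromophenyl of compound 1 stands apart at this position. Nothing available explains this pattern.

These compounds do not separate the effect of the halogen from that of its position. On these data alone, how an aminophenyl or a carboxyphenyl group would compare on this nitrogen remains open.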